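This account rests on a few compounds, and the source may have more. Where it says the series, first, only, none or still open, it means among the compounds named here.

Of the compounds shown here, three sharing one core have been measured in a functional assay on Caco-2 cells (Homo sapiens) for antiproliferative activity, read by MTT assay, with a stated time of 48 h; on this read-out lower numbers stand for stronger inhibition and higher numbers for weaker inhibition. Compound 1 `CCn1c(C(=O)NCCCN(C)C)ccc1C(CC)(CC)c1ccc(OCCC(O)(CC)CC)c(C)c1`, with (3-(dimethylamino)propyl)amino on the carbonyl carbon, gives 490 nM. Compound 2 `CCn1c(C(=O)NCCN)ccc1C(CC)(CC)c1ccc(OCCC(O)(CC)CC)c(C)c1`, with (2-aminoethyl)amino there, gives 1740 nM, and a 3.6-fold higher number from compound 1 to compound 2 (0.55 log units; beyond the scatter) is a modest step. Compound 3 `C#CC(C)OC(=O)c1ccc(C(CC)(CC)c2ccc(OCCC(O)(CC)CC)c(C)c2)n1CC` gives > 50000 nM, which is a limit of the assay and not a number. The three values shown include (the limit of > 50000 nM in this assay, at which 1 of the 3 values shown sits), so compound 3 stands at the weak end of the series, with no exact value.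

Both steps that bring in (1-methylprop-2-yn-1-yl)oxy are large: an at least 100-fold higher number from compound 1 to compound 3 (2.00 log units; beyond the scatter) and an at least 28-fold higher number from compound 2 to compound 3 (1.45 log units; beyond the scatter). Compound 4 `CCn1c(C(=O)Nc2cccc(C(F)(F)F)c2)ccc1C(CC)(CC)c1ccc(OCCC(O)(CC)CC)c(C)c1` changes that same place: (3-(trifluoromethyl)phenyl)amino in place of (1-methylprop-2-yn-1-yl)oxy on a carbonyl carbon. Like compound 1 at 490 nM and compound 2 at 1740 nM, compound 4 has an amino group on the carbonyl carbon, so a measurable number is expected in this assay. Among the measured compounds shown here, no measured compound carries the aromatic ring of the entering group, however, so only part of those large steps is expected to return. The expected change is an at least 5.0-fold lower number from compound 3 to compound 4 (0.69 log units; beyond the scatter), toward a lower number. Compound 4 is estimated at 10000 nM, with an expected range from 1500 nM to 50000 nM.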

Compound 4, half-maximal inhibitory concentration: > 50000 nM
Compound 4 ended at the assay's limit (the forecaster's own chance of this, stated with the estimate: 35%); middle value at least 5.0-fold (0.69 log units) away from the limit.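

At this carbonyl carbon, an amino link alone does not secure a measurable number in this assay: compound 4, with (3-(trifluoromethyl)phenyl)amino, gives > 50000 nM, which is a limit of the assay and not a number. With 3-(trifluoromethyl)phenyl on the amide-type nitrogen in place of either aminoalkyl chain, both steps are large: an at least 28-fold higher number from compound 2 to compound 4 (1.45 log units; beyond the scatter) and an at least 100-fold higher number from compound 1 to compound 4 (2.00 log units; beyond the scatter). Only compound 1 and compound 2, whose chains end in an amine, keep a measurable number, and the step from compound 3 to compound 4 cannot be read: the limit of > 50000 nM in this assay, at which 2 of the 4 values shown sit.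

The compounds shown do not tell whether the terminal amine or the saturated chain itself goes with the measurable numbers, a question that a chain ending in a hydroxyl group could address. Nor do they separate the aromatic ring from the trifluoromethyl group in compound 4, and an unsubstituted phenyl group or a phenyl ring carrying a dimethylaminoalkyl chain on the same nitrogen remains an open comparison.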